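Series notes: from compound 2 to compound 4

The compounds below may be only part of what the source reports. "The series", "measured", "known", "first", "only" and "open" are said of these compounds alone.

Compound 1 `C=C1C(=O)O[C@H]2CC3=C[C@H](C/C(C)=C/[C@@H](OC(=O)/C=C/c4ccccc4)[C@H]12)OC3=O`: 4800 nM
Compound 2 `C=C1C(=O)O[C@H]2CC3=C[C@H](C/C(C)=C/[C@@H](OC(=O)/C=C/c4ccc(N(C)C)cc4)[C@H]12)OC3=O`: > 10000 nM (a limit)
Compound 3 `C=C1C(=O)O[C@H]2CC3=C[C@H](C/C(C)=C/[C@@H](OC(=O)/C=C/c4ccc(C(F)(F)F)cc4)[C@H]12)OC3=O`: 5900 nM

In a functional assay on A549 cells (Homo sapiens) for cytotoxicity, read by MTT assay, with a stated time of 48 h (on this read-out lower numbers stand for stronger inhibition and higher numbers for weaker inhibition), compound 2 gives > 10000 nM, which is a limit of the assay and not a number. Compound 4 `C=C1C(=O)O[C@H]2CC3=C[C@H](C/C(C)=C/[C@@H](OC(=O)CCCCC)[C@H]12)OC3=O` is not yet measured and differs from compound 2 thus: pentyl in place of 2-(4-(dimethylamino)phenyl)ethenyl on a carbonyl carbon. The group that leaves carries the dimethylamino. Among the compounds with values here, two measured steps bear on this: an at least 2.0-fold higher number from compound 1 to compound 2 (0.31 log units; beyond the scatter) came with dimethylamino, while a 1.2-fold higher number from compound 1 to compound 3 (0.09 log units; within the scatter) came with trifluoromethyl. Within the data shown here, no measured step replaces the whole group, so the range stays wide. A modest fall in the number is expected, and the estimated step is an at least 1.5-fold lower number from compound 2 to compound 4 (0.18 log units; that floor lies within the scatter). The expected value for compound 4 is 6500 nM, with an estimated range from 2500 nM to 16000 nM.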

Compound 4, half-maximal inhibitory concentration: > 10000 nM
Compound 4: a limit, no number (the forecaster's own chance of this, stated with the estimate: 30%); middle value at least 1.5-fold (0.18 log units) away from the limit.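

In this assay compound 4 gives a limit and not a number, and the step from compound 2, between two limits, cannot be read. Pentyl in place of 2-phenylethenyl on a carbonyl carbon gives an at least 2.0-fold higher number from compound 1 to compound 4 (0.31 log units; beyond the scatter). At this position, a weaker result than that of compound 1 therefore also occurs without the dimethylamino of compound 2 and without any ring in the entering group.

As far as these compounds go, whether the loss follows from the missing aromatic ring, the missing double bond or the chain itself stays open. A 2-phenylethyl group, a longer chain or an amine at the chain end would help separate these.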